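Permeability notes on a three-compound matched series

The compounds below may be only part of what the source reports. "The series", "measured", "known", "first", "only" and "open" are said of these compounds alone.

In an ADME assay for permeability, using PAMPA, with a stated time of 30 min, at pH 7.4 (a higher number here means that the compound crosses the layer faster, a lower number that the compound crosses the layer more slowly), compound 2 `COc1ccc(F)cc1CNCCCNc1ccnc2cc(CCc3ccccc3)ccc12` gives 23 10^-6 cm/s. Compound 1 `COc1ccc(F)cc1CNCCCNc1ccnc2cc(CC3CCCCC3)ccc12` differs from it only at the saturated chain carbon bound to an aromatic carbon, (cyclohexyl in place of benzyl on a saturated chain carbon bound to an aromatic carbon), and in this assay compound 1 gives 23 10^-6 cm/s, so that no change at the digits printed from compound 2 to compound 1 (within the scatter). Compound 3 `COc1cccc(CNCCCNc2ccnc3cc(CCc4ccccc4)ccc23)c1O` carries the other core, (2-hydroxy-3-methoxyphenyl in place of 5-fluoro-2-methoxyphenyl on a saturated chain carbon bound to an amine nitrogen), and in this assay compound 3 gives 23 10^-6 cm/s; here too no change at the digits printed from compound 2 to compound 3 (within the scatter). The three measured values sit level with one another.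

Compound 4 `COc1cccc(CNCCCNc2ccnc3cc(CC4CCCCC4)ccc23)c1O` has not yet been measured. Within the data shown here, it differs from compound 3 by cyclohexyl in place of benzyl on a saturated chain carbon bound to an aromatic carbon, the same change, at the same place, as the one that carried compound 2 to compound 1. On the core of compound 3 the change is expected to repeat the earlier step, so the expected step of no change at the digits printed from compound 3 to compound 4 (within the scatter) mirrors no change at the digits printed from compound 2 to compound 1 (within the scatter). For compound 4 in this assay the estimate is 23 10^-6 cm/s, with a range expected from 14 10^-6 cm/s to 36 10^-6 cm/s.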

Compound 4, apparent permeability: 23 10^-6 cm/s
Estimate against measurement, compound 4: no gap at the digits printed, within the range that was stated.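

In this assay the cyclohexyl for benzyl change on the core of compound 3 reads no change at the digits printed from compound 3 to compound 4 (within the scatter), and it matches the step on the other core: the same change on two cores in this assay, no change at the digits printed (within the scatter) from compound 2 to compound 1 and no change at the digits printed (within the scatter) from compound 3 to compound 4, 1.0-fold (0.00 log units) apart, within the scatter of two such steps. The 2-hydroxy-3-methoxyphenyl for 5-fluoro-2-methoxyphenyl change, now read on the cyclohexyl side, gives no change at the digits printed from compound 1 to compound 4 (within the scatter), and it too matches its earlier step: the same change on two cores in this assay, no change at the digits printed (within the scatter) from compound 2 to compound 3 and no change at the digits printed (within the scatter) from compound 1 to compound 4, 1.0-fold (0.00 log units) apart, within the scatter of two such steps. Among these compounds, both changes therefore carry from one core to the other without a gap across these four compounds, but all four values are level, so the series shows only that no step appeared on either core, not how a step of visible size would transfer, and nothing beyond these compounds and this assay.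

From the compounds shown here alone, whether a carboxylic acid or an amide in place of the cyclohexyl or benzyl end would leave this assay level remains open. The same holds for a longer chain at that saturated carbon, where the four compounds give no reading.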